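Cytotoxicity of a Shared Core with Two Substituent Changes

This account rests on a few compounds, and the source may have more. Where it says the series, first, only, none or still open, it means among the compounds named here.

Compound 1 `Oc1ccccc1/C=N/c1sc2c(c1-c1nc3ccccc3s1)CCC2` and compound 2 `C(=C/c1ccccc1)\C=N\c1sc2c(c1-c1nc3ccccc3s1)CCC2` share a core and differ by 2-phenylethenyl in place of 2-hydroxyphenyl on a carbon with a double bond to nitrogen. In an ADME assay on HeLa cells (Homo sapiens) for cytotoxicity, read by MTT assay, with a stated time of 72 h (on this read-out higher numbers stand for lower toxicity in this test and lower numbers for higher toxicity in this test), compound 1 gives 168 ug/mL, and compound 2 gives 100 ug/mL; this step is a 1.7-fold lower number from compound 1 to compound 2 (0.23 log units; within the scatter). Compound 3 `Oc1ccccc1/C=N/c1sc2c(c1-c1nc3cc(Cl)ccc3s1)CCC2` differs from compound 1 by chloro in place of hydrogen on an aromatic carbon; in this assay compound 3 gives 251 ug/mL, which is a 1.5-fold higher number from compound 1 to compound 3 (0.17 log units; within the scatter). Compound 4 `Clc1ccc2sc(-c3c(/N=C/C=C/c4ccccc4)sc4c3CCC4)nc2c1` has not yet been measured. It differs from compound 3 by 2-phenylethenyl in place of 2-hydroxyphenyl on a carbon with a double bond to nitrogen, the same change that leads from compound 1 to compound 2, at a place described in the same words. Among the measured compounds shown here, with only three measured compounds it is not known whether this change behaves alike on both cores, so the measured step is taken as the best guide. The step from compound 3 to compound 4 is expected to be a 1.7-fold lower number from compound 3 to compound 4 (0.22 log units; within the scatter), set beside the earlier one because a 1.7-fold lower number from compound 1 to compound 2 (0.23 log units; within the scatter) was a small step. Compound 4 is therefore estimated at 150 ug/mL in this assay, with a range from 80 ug/mL to 300 ug/mL.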

Compound 4, half-maximal cytotoxic concentration: 200 ug/mL
Compound 4: middle estimate off by 1.3-fold (0.12 log units), on the low side, and the stated range covers the measured number.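

In this assay, putting 2-phenylethenyl in place of 2-hydroxyphenyl on the chloro-bearing core gives a 1.3-fold lower number from compound 3 to compound 4 (0.10 log units; within the scatter), and this step matches the one seen on the core without chloro: the same change on two cores in this assay, a 1.7-fold lower number (0.23 log units; within the scatter) from compound 1 to compound 2 and a 1.3-fold lower number (0.10 log units; within the scatter) from compound 3 to compound 4, 1.3-fold (0.13 log units) apart, within the scatter of two such steps. Read the other way, putting chloro in place of hydrogen among the 2-phenylethenyl compounds gives a 2.0-fold higher number from compound 2 to compound 4 (0.30 log units; within the scatter), and this step matches the one seen among the 2-hydroxyphenyl compounds: the same change on two cores in this assay, a 1.5-fold higher number (0.17 log units; within the scatter) from compound 1 to compound 3 and a 2.0-fold higher number (0.30 log units; within the scatter) from compound 2 to compound 4, 1.3-fold (0.13 log units) apart, within the scatter of two such steps. Across these four compounds, each change carries from one core to the other with no difference that can be told from scatter, but all the steps are themselves within the scatter, so this shows only that they stay small here, not that either change has a real effect of a fixed size.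

The compounds shown leave open whether bromo or methoxy in place of chloro, or an amine or a longer chain in place of 2-phenylethenyl, would also give steps this small. Going by these compounds, whether the two changes would carry over as well on any other core also remains open.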